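Triazole phenol amides: hexyl to 3-chlorophenyl

The compounds below may be only part of what the source reports. "The series", "measured", "known", "first", "only" and "open" are said of these compounds alone.

Compound 1 `CCCCCCc1cn(-c2ccc(O)c(C(=O)N3CCCCC3)c2)nn1` and compound 3 `CCCCCCc1cn(-c2ccc(C(=O)N3CCCCC3)c(O)c2)nn1` are built from the same atoms joined differently; the difference between the two cores is not broken down here. In a functional assay on RAW264.7 cells (Mus musculus) for inhibition, read by Griess assay, with a stated time of 20 h (on this read-out higher numbers stand for weaker inhibition and lower numbers for stronger inhibition), compound 1 gives > 20000 nM, which is a limit of the assay. Compound 3 gives > 20000 nM in this assay, also a limit. Compound 2 `O=C(c1cc(-n2cc(-c3cccc(Cl)c3)nn2)ccc1O)N1CCCCC1` carries the change (3-chlorophenyl in place of hexyl on an aromatic carbon). In this assay compound 2 gives > 20000 nM, again a limit. The step that the two limits leave unreadable from compound 1 to compound 2 is therefore unreadable, as the limit of > 20000 nM in this assay, at which 3 of the 3 values shown sit, shows. Compound 4 `O=C(c1ccc(-n2cc(-c3cccc(Cl)c3)nn2)cc1O)N1CCCCC1` carries the same change (3-chlorophenyl in place of hexyl on an aromatic carbon), at a place described in the same words. Because the limit of > 20000 nM in this assay, at which 3 of the 3 values shown sit, holds for every measured compound, the expected step is a step that the limit leaves unreadable from compound 3 to compound 4. Compound 4 is expected to give about 30000 nM in this assay, between 15000 nM and 80000 nM, most probably reported only as a limit.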

Compound 4, half-maximal inhibitory concentration: > 20000 nM
Compound 4: no number, only a limit (the forecaster's own chance of this, stated with the estimate: 85%); the middle value lies beyond the limit too.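

The step between compound 3 and compound 4 cannot be read, and neither compound gives a number: the limit of > 20000 nM in this assay, at which 4 of the 4 values shown sit. Going by these compounds, whether 3-chlorophenyl or hexyl gives stronger inhibition, on either core, stays open in this assay.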